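Compound 3 to compound 4: little change expected

A few compounds are considered here, and "the series" means these few. Any claim that something is new, unique, unknown or untested is made for them only; others in the source may bear on it.

In a functional assay on HepG2 cells (Homo sapiens) for antiproliferative activity, read by spectrophotometry, with a stated time of 2 days (on this read-out lower numbers stand for stronger inhibition of growth and higher numbers for weaker inhibition of growth), compound 3 `Cc1ccc(Nc2ncc(C(F)(F)F)c(N3Cc4cccc(N(C)S(C)(=O)=O)c4C3)n2)c(C)c1` gives 19100 nM and compound 2 `CN(c1cccc2c1CN(c1nc(Nc3cc(C(F)(F)F)cc(C(F)(F)F)c3)ncc1C(F)(F)F)C2)S(C)(=O)=O` gives 10300 nM as values within the scatter of each other. Compound 1 `COc1ccc(Nc2ncc(C(F)(F)F)c(N3Cc4cccc(N(C)S(C)(=O)=O)c4C3)n2)cc1C(F)(F)F` gives > 30000 nM as a limit and not a number. Compound 4 `CN(c1cccc2c1CN(c1nc(Nc3cccc(C(F)(F)F)c3)ncc1C(F)(F)F)C2)S(C)(=O)=O` differs through 3-(trifluoromethyl)phenyl in place of 2,4-dimethylphenyl on a nitrogen on an aromatic ring from compound 3, with 3-(trifluoromethyl)phenyl in place of 2,4-dimethylphenyl on a nitrogen on an aromatic ring. Among the compounds with values here, the one measured step at this place is an at least 1.5-fold lower number from compound 1 to compound 3 (0.19 log units; that floor lies within the scatter) and it rests on a limit. Compound 2 with 10300 nM also carries trifluoromethyl on that ring yet sits within the scatter of compound 3. No step beyond the scatter is therefore expected in this assay for this change. The estimate means an expected 1.1-fold lower number from compound 3 to compound 4 (0.05 log units; within the scatter) on this read-out. Compound 4 is estimated at 17000 nM and 8000 nM to 32000 nM is its expected range.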

Compound 4, concentration for 50% growth inhibition: > 30000 nM
Compound 4: only a limit was reported; the forecaster's own chance of this, stated with the estimate: 20%; middle value at least 1.7-fold (0.24 log units) away from the limit.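

In this assay, within the data shown here, hydrogen in place of trifluoromethyl on an aromatic carbon gives an at least 2.9-fold higher number from compound 2 to compound 4 (0.46 log units; beyond the scatter), the first step on this ring to lie beyond the scatter. In contrast, 3-(trifluoromethyl)phenyl in place of 2,4-dimethylphenyl gives an at least 1.5-fold higher number from compound 3 to compound 4 (0.19 log units; that floor lies within the scatter), so the size of this change remains unresolved. Compound 4 gives a limit and not a number, and its step with compound 1 cannot be read: the limit of > 30000 nM in this assay, at which 2 of the 4 values shown sit.

From the compounds shown here alone, it remains open how an amine or a carboxylic acid on that aromatic carbon would compare with the trifluoromethyl of compound 2.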